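The source may report more compounds than this note shows. Statements on the series, on what has been measured and on what is new or still open speak of the compounds shown alone.

In a functional assay on OVCAR-4 cells (Homo sapiens) for inhibition, read by sulforhodamine B assay, with a stated time of 48 h (a higher number here means a weaker inhibitor of growth, a lower number a stronger inhibitor of growth), compound 1 `N#Cc1c(-c2nnc(O)c3nn(-c4ccc(Cl)cc4)cc23)nn(-c2ccccc2)c1-c1ccccc1` gives 4380 nM, and compound 2 `N#Cc1c(-c2nnc(-c3ccccc3)c3nn(-c4ccccc4)cc23)nn(-c2ccccc2)c1-c1ccccc1` gives 63000 nM, the higher of the two numbers, with a gap beyond the scatter. Compound 3 `N#Cc1c(-c2nnc(-c3ccccc3)c3nn(-c4ccc(Cl)cc4)cc23)nn(-c2ccccc2)c1-c1ccccc1` follows from compound 2 through (chloro in place of hydrogen on an aromatic carbon), which reads as phenyl to 4-chlorophenyl, with chloro in place of hydrogen on an aromatic carbon. Among the measured compounds shown here, no measured pair isolates this change, so the expectation is only a modest fall in the number, and the estimated move is a 2.1-fold lower number from compound 2 to compound 3 (0.32 log units; beyond the scatter). For compound 3 the expected value is 30000 nM, with an estimated range of 10000 nM to 80000 nM.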

Compound 3, concentration for 50% growth inhibition: 7660 nM
Estimate against measurement, compound 3: 3.9-fold (0.59 log units) above, and the stated range ends above it.
By their numbers in this assay, from the lowest: compounds 1 and 3 (each within the scatter of the next); then compound 2.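

In this assay, among the compounds shown here, phenyl to 4-chlorophenyl, para to a large group, gives an 8.2-fold lower number from compound 2 to compound 3 (0.92 log units; beyond the scatter) and is the first single-place reading of this change. With 4-chlorophenyl in place, phenyl in place of hydroxy on an aromatic carbon gives a 1.7-fold higher number from compound 1 to compound 3 (0.24 log units; within the scatter) and so separates the two groups by no more than the scatter. Nothing at hand accounts for the size of the chloro step.

On these data alone, whether that step carries over to compound 1 remains open. Also open, as far as these compounds go, is how fluoro or methoxy would read at the chloro place, or an amine or a carboxylic acid in place of hydroxy.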